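A few compounds are considered here, and "the series" means these few. Any claim that something is new, unique, unknown or untested is made for them only; others in the source may bear on it.

Measured compounds:
- compound 1, `CCc1ccccc1NC(=O)N[C@@H](C)c1ccccc1`: 100%
- compound 2, `COc1ccccc1NC(=O)N[C@@H](C)c1ccccc1`: 99%
- compound 3, `CC(=O)c1ccccc1NC(=O)N[C@@H](C)c1ccccc1`: 97%

Compound 1 has the highest of the three numbers in an ADME assay on the whole organism with Oryza sativa as the target, tested at 1 uM (a higher number here means a weaker effect of the compound at the concentration tested, a lower number a stronger effect), but its neighbours sit within the scatter of it: compound 2 is a step of a number 1 percentage points lower from compound 1 to compound 2 (within the scatter) away, and compound 3, the furthest, a step of a number 3 percentage points lower from compound 1 to compound 3 (within the scatter). Between compound 2 and compound 3 the step is a number 2 percentage points lower from compound 2 to compound 3 (within the scatter), again within the scatter. All three compounds thus read close to the top of the scale.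

Compound 4, `CCc1cccc(CC)c1NC(=O)N[C@@H](C)c1ccccc1`, is not yet measured in this assay. Compared with compound 1 the difference is ethyl in place of hydrogen on an aromatic carbon; the new group enters on an aromatic carbon of a six-membered aromatic ring of carbon only, ortho to a large group and meta to an ethyl group.

The steps from compound 1 to compound 2 and from compound 1 to compound 3 bear on this change in that they alter the same ring position type, and both stayed within the scatter. For the measured compounds named here, no measured step shows what an added ethyl on this ring does. Given that every measured variant of this ring reads near the top, the step from compound 1 to compound 4 in this assay is expected to be a number 2 percentage points lower from compound 1 to compound 4 (within the scatter), none beyond the scatter. Compound 4 is therefore estimated at 98%, in the range 88% to 100%.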

Compound 4, a percentage reported as activity, at one concentration (the size of the read-out at that concentration, not a potency): 93%
Beside the measured number, compound 4's estimate is 5 percentage points above it; measured number inside the range.
By their numbers in this assay, from the lowest: compounds 4, 3, 2 and 1 (each within the scatter of the next).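

In this assay, ethyl in place of hydrogen on an aromatic carbon, ortho to a large group and meta to an ethyl group, gives a step of a number 7 percentage points lower from compound 1 to compound 4 (within the scatter). Compounds 1, 2 and 3 all carry hydrogen at this place, so this is the only step shown that speaks to it, and it shows that an added ethyl group there leaves the read-out within the scatter of compound 1. No measurement shown offers an explanation for this step.

On these data alone, whether an amine, a carboxylic acid or a longer chain at this place would give a step beyond the scatter stays open. The rest of the shared core is the same in all four compounds, so what a change there would do is also unknown.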